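Losing the 3,5-dimethoxyphenyl group in a growth-inhibition series

This account rests on a few compounds, and the source may have more. Where it says the series, first, only, none or still open, it means among the compounds named here.

Within the data shown here, compound 3 `COc1cc(Nc2ncc(C(F)(F)F)c(N3Cc4cccc(N(C)S(C)(=O)=O)c4C3)n2)cc(OC)c1` gives 1800 nM in a functional assay on HepG2 cells (Homo sapiens) for antiproliferative activity, read by spectrophotometry, with a stated time of 2 days (on this read-out higher numbers stand for weaker inhibition of growth and lower numbers for stronger inhibition of growth), and holds the lowest number so far. In this assay compound 2 `COc1cc(Nc2ncc(C(F)(F)F)c(N3Cc4cccc(N(C)S(C)(=O)=O)c4C3)n2)c(OC)cc1Cl` gives 25600 nM as its value. Compound 1 `Cc1ccc(Nc2ncc(C(F)(F)F)c(N3Cc4cccc(N(C)S(C)(=O)=O)c4C3)n2)cc1C` gives > 30000 nM as a limit and not a number. Both gaps are large: the data show an at least 16-fold lower number from compound 1 to compound 3 (1.22 log units; beyond the scatter) and also a 14-fold lower number from compound 2 to compound 3 (1.15 log units; beyond the scatter) as steps beyond the scatter. The step of an at least 1.1-fold lower number from compound 1 to compound 2 (0.06 log units; that floor lies within the scatter) sets those two apart by no clear margin.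

Compound 4 `Cc1cc(Cl)ccc1Nc1ncc(C(F)(F)F)c(N2Cc3cccc(N(C)S(C)(=O)=O)c3C2)n1` carries 4-chloro-2-methylphenyl in place of 3,5-dimethoxyphenyl on a nitrogen on an aromatic ring and so loses the group that, among the measured compounds, only compound 3 has. Read backwards, a 14-fold lower number from compound 2 to compound 3 (1.15 log units; beyond the scatter) points to a large rise in this assay for compound 4 as well, although three compounds offer thin support. The estimate is an 8.3-fold higher number from compound 3 to compound 4 (0.92 log units; beyond the scatter) as a large step towards weaker inhibition of growth. Compound 4 is expected near 15000 nM with an estimated range of 4000 nM to 40000 nM overall.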

Compound 4, concentration for 50% growth inhibition: 19600 nM
Compound 4: the middle estimate sits 1.3-fold (0.12 log units) below what was measured, and the stated range covers the measured number.
By their numbers in this assay, from the lowest: compound 3; then compounds 4 and 2 (each within the scatter of the next). At a limit, above all of these: compound 1.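

Replacing the 3,5-dimethoxyphenyl group on this nitrogen with a quite different ring gives a large change in this assay: an 11-fold higher number from compound 3 to compound 4 (1.04 log units; beyond the scatter) shows that the gap seen with compound 2 is not specific to that one replacement. Compound 4 has no methoxy group and compound 2 has two, yet a 1.3-fold lower number from compound 2 to compound 4 (0.12 log units; within the scatter) leaves them within the scatter, so methoxy groups alone do not bring the low number of compound 3. Compound 1 gives a limit and not a number, so the step of an at least 1.5-fold lower number from compound 1 to compound 4 (0.18 log units; that floor lies within the scatter) does not put these two compounds in order: the limit of > 30000 nM in this assay, at which 1 of the 4 values shown sits.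

As far as these compounds go, with a single compound holding the low number, it remains open whether both methoxy groups of compound 3 are needed. From the compounds shown here alone, how a phenyl ring with one methoxy group, or one carrying an amine or a carboxylic acid, would behave on this nitrogen also remains open.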